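A Ring Swap at the Assay's Limit

This account rests on a few compounds, and the source may have more. Where it says the series, first, only, none or still open, it means among the compounds named here.

Compound 1 `COc1cccc(OCCC(C)(C)C)c1C(=O)/C=C/c1ccc(O)cc1`: > 30000 nM (a limit)
Compound 2 `O=C(/C=C/c1ccc(O)cc1)c1c(O)cccc1OCC1CCCCC1`: > 30000 nM (a limit)
Compound 3 `CC(C)(C)CCOc1cccc(O)c1C(=O)/C=C/c1ccc(S(N)(=O)=O)cc1`: 2950 nM

In a functional assay on NCI-H23 cells (Homo sapiens) for antiproliferative activity, read by sulforhodamine B assay (on this read-out lower numbers stand for stronger inhibition of growth and higher numbers for weaker inhibition of growth), compound 2 stands at > 30000 nM, which is a limit of the assay and not a number. Compound 1 sits at the same limit, and only compound 3 gives a measured number.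

Compound 4 `O=C(/C=C/c1ccc(O)cc1)c1c(O)cccc1OCCC1CCCC1` has cyclopentylmethyl in place of cyclohexyl on a saturated chain carbon bound to an oxygen on an aromatic ring. Among the measured compounds shown here, no measured pair shows what this swap does. The expectation rests on compound 2, whose limit of > 30000 nM is the starting point. The step expected is a number no higher from compound 2 to compound 4 (the limit leaves the size open), with no change beyond the scatter. Compound 4 is estimated at 30000 nM, with an expected range from 12000 nM to 60000 nM.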

Compound 4, concentration for 50% growth inhibition: 3370 nM
Beside the measured number, compound 4's estimate is 8.9-fold (0.95 log units) above it; measured number below the stated range.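

Cyclopentylmethyl in place of cyclohexyl on a saturated chain carbon bound to an oxygen on an aromatic ring gives an at least 8.9-fold lower number from compound 2 to compound 4 (0.94 log units; beyond the scatter) in this assay. The earlier compounds shown here offered no pair differing in one place, so only now is it clear that this position responds to how the same six carbons are arranged. The full size of the step stays unknown since the value of compound 2 is a limit: the limit of > 30000 nM in this assay, at which 2 of the 4 values shown sit.

From the compounds shown here alone, whether a cyclobutyl ring, a longer chain or an amine at this position would hold the gain remains open.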